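This account rests on a few compounds, and the source may have more. Where it says the series, first, only, none or still open, it means among the compounds named here.

Compound 1 `COc1cc(/C=C/C(=O)/C=C/c2nc3ccccc3n2C)ccc1O`: 4700 nM
Compound 2 `COc1cc(/C=C/C(=O)/C=C/c2nc3cc(C)ccc3n2C)ccc1O`: 4700 nM
Compound 3 `COc1cc(/C=C/C(=O)/C=C/c2nc3c(C)cccc3n2C)ccc1O`: 1000 nM

These values come from a functional assay on SH-SY5Y cells (Homo sapiens) for cytotoxicity, read by MTT assay, with a stated time of 48 h; on this read-out lower numbers stand for stronger inhibition and higher numbers for weaker inhibition. Compound 2 stands level with compound 1, the two sharing the highest number of the three, while compound 3 has the lowest. The unmeasured compound 4 `COc1cc(/C=C/C(=O)/C=C/c2nc3c(C)c(C)ccc3n2C)ccc1O` differs from compound 2 by one change (methyl in place of hydrogen on an aromatic carbon), a methyl in place of hydrogen on an aromatic carbon. Two measured steps make this kind of swap. Adding the methyl of compound 2 gave no change at the digits printed from compound 1 to compound 2 (within the scatter), and adding the methyl of compound 3 gave a 4.7-fold lower number from compound 1 to compound 3 (0.67 log units; beyond the scatter), a modest step. For the measured compounds named here, compound 4 holds both of these methyl groups, so the methyl it gains over compound 2 is the one that compound 3 carries, which makes the second step the closer guide. Going by the values given here, no measured compound holds both groups, so that step may not carry over in full. A modest lowering of similar size is therefore expected (a 3.9-fold lower number from compound 2 to compound 4 (0.59 log units; beyond the scatter)). Compound 4 is estimated at 1200 nM with an expected range (from 450 nM to 3500 nM).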

Compound 4, half-maximal inhibitory concentration: 19000 nM
Compound 4: the middle estimate sits 16-fold (1.20 log units) below what was measured; measured number outside the range, above it.
By their numbers in this assay, from the lowest: compound 3; then compounds 1 and 2 (each within the scatter of the next); then compound 4.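

The methyl that enters ortho to a fused ring and ortho to a methyl group gives a 4.0-fold higher number from compound 2 to compound 4 (0.61 log units; beyond the scatter) in this assay, so this swap moves the number the opposite way once the methyl of compound 2 is present: the same change on two cores in this assay, a 4.7-fold lower number (0.67 log units; beyond the scatter) from compound 1 to compound 3 and a 4.0-fold higher number (0.61 log units; beyond the scatter) from compound 2 to compound 4, 19-fold (1.28 log units) apart, beyond the scatter of two such steps.
The methyl of compound 2, which left the number unchanged on the core of compound 1, gives a 19-fold higher number from compound 3 to compound 4 (1.28 log units; beyond the scatter) on the core of compound 3: the same change on two cores in this assay, no change at the digits printed (within the scatter) from compound 1 to compound 2 and a 19-fold higher number (1.28 log units; beyond the scatter) from compound 3 to compound 4, 19-fold (1.28 log units) apart, beyond the scatter of two such steps.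
In these compounds, the effect of each methyl therefore depends on whether the other is present, so neither can be read alone.

The compounds shown do not tell what lies behind this dependence. As far as these compounds go, it also remains open whether an amine, a methoxy group or a longer chain in place of the entering methyl would raise the number as well.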